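Swapping a methoxymethyl for a pyridyl: expected clearance

A few compounds are considered here, and "the series" means these few. Any claim that something is new, unique, unknown or untested is made for them only; others in the source may bear on it.

Compound 1 `O=c1n(Cc2nc(-c3nccs3)cn2CCCCO)c2cnccc2n1C1CC1`: in an ADME assay on microsomes from liver (Homo sapiens) for metabolic stability (on this read-out lower numbers stand for slow clearance and higher numbers for fast clearance), compound 1 gives < 8 mL.min-1.g-1, which is a limit of the assay rather than a number.
Compound 2 `COCc1cn(CCCCO)c(Cn2c(=O)n(C3CC3)c3ccncc32)n1`: in this assay compound 2 gives 9 mL.min-1.g-1.
Compound 3 `COC(=O)c1nc(Cn2c(=O)n(C3CC3)c3ccncc32)n(CCCCO)c1C`: in this assay compound 3 gives 9 mL.min-1.g-1.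

All three share one core, and all three are cleared slowly in this assay. Compound 2 stands level with compound 3 at the digits shown, a difference within the usual scatter. The step from the thiazolyl compound to the methoxymethyl compound reads an at least 1.1-fold higher number from compound 1 to compound 2 (0.05 log units; that floor lies within the scatter), and since the starting point is only a limit (the limit of < 8 mL.min-1.g-1 in this assay, at which 1 of the 3 values shown sits), that step cannot be sized further.

Compound 4 `O=c1n(Cc2nc(-c3cccnc3)cn2CCCCO)c2cnccc2n1C1CC1` carries pyridin-3-yl in place of methoxymethyl on an aromatic carbon. Among the compounds with values here, this change brings back an aromatic ring at the same place where compound 1 already carried one, so the only measured step that bears on it is the one from compound 1 to compound 2, which lies within the scatter. No change beyond the scatter is therefore expected in this assay, with at most a drift back toward slow clearance.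

Compound 4 is expected to show 8 mL.min-1.g-1, with a range from 4 mL.min-1.g-1 to 16 mL.min-1.g-1, a step of a 1.1-fold lower number from compound 2 to compound 4 (0.05 log units; within the scatter) that is estimated to stay within the scatter.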

Compound 4, intrinsic clearance in microsomes: < 8 mL.min-1.g-1
Compound 4 gave a limit, no number (the forecaster's own chance of this, stated with the estimate: 40%); the middle value sits exactly at the limit.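

Compound 4 gives a limit of the assay rather than a number, and it is the second compound with an aromatic ring on this carbon, next to the ring nitrogen, to end there: the limit of < 8 mL.min-1.g-1 in this assay, at which 2 of the 4 values shown sit. Putting pyridin-3-yl where compound 2 carries methoxymethyl gives an at least 1.1-fold lower number from compound 2 to compound 4 (0.05 log units; that floor lies within the scatter), so this position accepts a six-membered aromatic ring in place of a small open chain, and clearance in this assay stays slow. The step from compound 1 to compound 4 cannot be read, since both values are limits, and the 1,3-thiazol-2-yl and pyridin-3-yl groups therefore cannot be ranked against each other.

On these data alone, the true clearance of compound 1 and compound 4 lies hidden behind the limit, so the real size of the gap between either of them and compound 2 remains unknown. Also open, as far as these compounds go, is whether an amine or a carboxylic acid on this same carbon would stay as slowly cleared, and whether a longer chain could take the place of the 4-hydroxybutyl group.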